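The source may report more compounds than this note shows. Statements on the series, on what has been measured and on what is new or still open speak of the compounds shown alone.

- compound 1 `O=C(CN1CCN(c2nnc(Cc3ccncc3)c3ccccc23)CC1)Nc1cccc(F)c1` gives 6130 nM in the test below
- compound 2 `O=C(CN1CCN(c2nnc(Cc3ccncc3)c3ccccc23)CC1)Nc1ccc(F)c(C(F)(F)F)c1` gives 1110 nM in the same test

Both compounds were tested in a functional assay on HT-29 cells (Homo sapiens) for cytotoxicity, read by MTT assay, with a stated time of 72 h (a lower number here means a stronger inhibitor, a higher number a weaker inhibitor), and, of these two numbers, compound 2 has the lower one at 1110 nM so far. Compound 3 `O=C(CN1CCN(c2nnc(Cc3ccncc3)c3ccccc23)CC1)Nc1cc(C(F)(F)F)ccc1Cl` keeps the core of compound 2 and changes only the group on an amide-type nitrogen, where 2-chloro-5-(trifluoromethyl)phenyl stands in place of 4-fluoro-3-(trifluoromethyl)phenyl. The counted difference is 2-chloro-5-(trifluoromethyl)phenyl in place of 4-fluoro-3-(trifluoromethyl)phenyl on an amide-type nitrogen and it leaves the size of the group unchanged. Among the compounds with values here, one measured step bears on this change, as it altered the group at the same place: a 5.5-fold lower number from compound 1 to compound 2 (0.74 log units; beyond the scatter) is a modest step and is the only guide available. Within the data shown here, no measured compound carries the entering group, so the data do not settle a direction. A step no larger than that modest one is expected, probably not clearly beyond the scatter. The estimated step is a 1.4-fold higher number from compound 2 to compound 3 (0.13 log units; within the scatter) in this assay and this remains only an expectation. The expected value for compound 3 is 1500 nM within an estimated range of 450 nM to 5000 nM in this test.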

Compound 3, half-maximal inhibitory concentration: 4810 nM
For compound 3 the middle estimate is 3.2-fold (0.51 log units) below the measured one, within the range that was stated.
By their numbers in this assay, from the lowest: compound 2; then compounds 3 and 1 (each within the scatter of the next).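

In this assay the place on the amide-type nitrogen responds even to a swap that leaves the size of the group unchanged, since moving to the 2-chloro-5-(trifluoromethyl)phenyl group gives a clear rise (a 4.3-fold higher number from compound 2 to compound 3 (0.64 log units; beyond the scatter)). Compound 3 still carries a trifluoromethyl group, yet it cannot be told apart from compound 1, which has none (a 1.3-fold lower number from compound 1 to compound 3 (0.11 log units; within the scatter)), so among these three compounds the trifluoromethyl group alone does not go with the lower number of compound 2. Nothing measured here explains why these two closely matched groups behave differently.

The two groups differ both in the halogen, chlorine against fluorine, and in how the substituents are arranged on the ring, so these compounds cannot show which of the two differences matters. Going by these compounds, how this place would respond to a phenyl ring carrying an amine or a carboxylic acid, or to a longer chain between the amide-type nitrogen and the ring, also stays open.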